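Cytotoxicity notes on the shared core: outlook for compound 3

The source may hold more compounds than are shown below. What is called first, only, known or untested is meant among the compounds shown, and "the series" means these compounds.

Compound 1 `O=CNC[C@H]1CN(c2ccc(-n3cc(-c4ccccn4)cn3)c(F)c2)C(=O)O1` and compound 2 `O=C1O[C@@H](CNC(=O)C(F)(F)F)CN1c1ccc(-n2cc(-c3ccccn3)cn2)c(F)c1` share one core. In an ADME assay on HEK293-A cells (Homo sapiens) for cytotoxicity, read by MTT assay, with a stated time of 48 h (on this read-out higher numbers stand for weaker inhibition and lower numbers for stronger inhibition), compound 1 gives > 400 ug/mL, a limit of the assay. In this assay compound 2 gives > 400 ug/mL, likewise a limit, so compound 2 sits at the top of what the numbers show, (the limit of > 400 ug/mL in this assay, at which 2 of the 2 values shown sit). The step that the two limits leave unreadable from compound 1 to compound 2 cannot be read. Compound 3 `CONC(=O)[C@H]1CN(c2ccc(-n3cc(-c4ccccn4)cn3)c(F)c2)C(=O)O1` differs from compound 2 by methoxycarbamoyl in place of (((trifluoromethyl)carbonyl)amino)methyl on a saturated ring carbon. No readable measured step bears on this change. The expected step that the limit leaves unreadable from compound 2 to compound 3 is therefore none beyond the scatter. Compound 3 is estimated at 450 ug/mL, with a range from 200 ug/mL to 1000 ug/mL, most likely again reported only as a limit.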

Compound 3, half-maximal inhibitory concentration: > 400 ug/mL
Compound 3: a limit, no number; the forecaster's own chance of this, stated with the estimate: 80%; the middle value lies beyond the limit too.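

Within the data shown here, compound 3, like compound 1 and compound 2, gives only a limit, so no step among the three can be read: the limit of > 400 ug/mL in this assay, at which 3 of the 3 values shown sit.

As far as these compounds go, whether these three side groups differ at all in this assay remains open, as does any numerical value for the shared core.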